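The source may hold more compounds than are shown below. What is called first, only, known or untested is meant among the compounds shown, and "the series" means these compounds.

Measured in a physicochemical assay for lipophilicity, read by LC-MS, using the shake flask method, in phosphate buffer, with a stated time of 50 min, at pH 7.4; a lower number here means a more polar compound, a higher number a more lipophilic compound:
- compound 1 `CCCC(=O)OCCCCCC(=O)N[C@H](C(=O)N1C[C@H](O)C[C@H]1C(=O)NCc1ccc(-c2scnc2C)cc1)C(C)(C)C`: 0.5
- compound 2 `CCCC(=O)NCCCCCC(=O)N[C@H](C(=O)N1C[C@H](O)C[C@H]1C(=O)NCc1ccc(-c2scnc2C)cc1)C(C)(C)C`: 2.2
- compound 3 `Cc1ncsc1-c1ccc(CNC(=O)[C@@H]2C[C@@H](O)CN2C(=O)[C@@H](NC(=O)CCCCCNC(=O)C2CCCCC2)C(C)(C)C)cc1`: 1.4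

Compound 3, at 1.4, stands second highest of the three, below compound 2 and above compound 1. Compound 4 `Cc1ncsc1-c1ccc(CNC(=O)[C@@H]2C[C@@H](O)CN2C(=O)[C@@H](NC(=O)CCCCCOC(=O)C2CCCCC2)C(C)(C)C)cc1` keeps the rest of compound 3 and makes one swap: (cyclohexylcarbonyl)oxy in place of (cyclohexylcarbonyl)amino on a saturated chain carbon, five bonds along the chain from a carbonyl carbon. Among the compounds with values here, the closest precedent is the reverse swap with a propyl group, a number 1.70 log units higher from compound 1 to compound 2 (beyond the scatter), a large step. The comparison a number 0.90 log units higher from compound 1 to compound 3 (beyond the scatter) is a modest step, and so is a number 0.80 log units lower from compound 2 to compound 3 (beyond the scatter), where cyclohexyl replaces propyl. Read backward, the large step points to a lower number in this assay, but it rests on a single pair, so a smaller fall is expected. The expected change is a number 0.80 log units lower from compound 3 to compound 4 (beyond the scatter). The estimate for compound 4 is 0.6, with a range from -0.4 to 2.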

Compound 4, distribution coefficient: 1.1
Compound 4: the middle estimate sits 0.50 log units below what was measured; the measured number falls inside the stated range.
By their numbers in this assay, from the lowest: compound 1; then compounds 4 and 3 (each within the scatter of the next); then compound 2.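

With cyclohexyl on the carbonyl carbon, (cyclohexylcarbonyl)oxy in place of (cyclohexylcarbonyl)amino gives a number 0.30 log units lower from compound 3 to compound 4 (within the scatter) in this assay, whereas the same exchange with propyl, read the other way, gave a number 1.70 log units higher from compound 1 to compound 2 (beyond the scatter), so its effect here depends on the group it carries. Cyclohexyl in place of propyl gives a number 0.60 log units higher from compound 1 to compound 4 (beyond the scatter), opposite in direction to a number 0.80 log units lower from compound 2 to compound 3 (beyond the scatter), while changing both places gives a number 1.10 log units lower from compound 2 to compound 4 (beyond the scatter). No measurement shown here accounts for this difference. On these data alone, whether a phenyl group on the carbonyl carbon, or a longer chain, would follow the propyl pair or the cyclohexyl pair stays open.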